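Fluoro for cyano on the aryl of compound 1

A few compounds are considered here, and "the series" means these few. Any claim that something is new, unique, unknown or untested is made for them only; others in the source may bear on it.

Working notes on a small set of piperidinyl acetanilides read in a functional assay on HEK293 cells for agonist activity at D(4) dopamine receptor (Homo sapiens), read by FLIPR; a higher number here means a larger maximal response, a lower number a smaller maximal response. Compound 1 `Cc1cccc(NC(=O)CN2CCC(c3ccccc3C#N)CC2)c1` gives 71% in this assay. Compound 2 `Cc1cc(C(=O)NCN2CCC(c3cccc[n+]3[O-])CC2)ccc1F` gives 67% in this assay, and compound 3 `Cc1ccc([N+](=O)[O-])cc1NC(=O)CN1CCC(c2cccc[n+]2[O-])CC1` gives 76% in this assay. The three numbers lie within the usual scatter of one another, so compound 1 cannot be set apart from compound 2 or compound 3 on these data; its number is simply one of three that sit close together.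

Compound 4 `Cc1cccc(NC(=O)CN2CCC(c3ccccc3F)CC2)c1` has not yet been measured in this assay. It differs from compound 1 in one place: fluoro in place of cyano on an aromatic carbon. For the measured compounds named here, no measured pair in the set shows this change, so the size of its effect has to be guessed rather than read off. Going by the values given here, with three compounds of different aryl groups and different anilide substituents all falling within the scatter of each other, the series so far gives no sign that a change on the aryl of this kind moves the maximal response by much.

The expectation for compound 4 is therefore a number close to that of compound 1, with the step of a number 2 percentage points lower from compound 1 to compound 4 (within the scatter) expected to stay within the scatter. Compound 4 is estimated at 69% in this assay, within a range of 54% to 84%.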

Compound 4, largest response reached (reported as efficacy), in percent of the reference or control that the assay uses: 57%
Compound 4: middle estimate off by 12 percentage points, on the high side, and the stated range covers the measured number.
By their numbers in this assay, from the lowest: compounds 4, 2, 1 and 3 (each within the scatter of the next, the first and the last beyond it).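

For the compounds shown here, the change from 2-cyanophenyl to 2-fluorophenyl, on an aromatic carbon ortho to a large group, gives the first step that can be read at a single place: a number 14 percentage points lower from compound 1 to compound 4 (beyond the scatter) in this assay. The earlier compounds shown here differ from one another in several places at once and sit within the scatter of each other, so they could not show that the group at this position matters for the maximal response; this pair shows that it does, at least for these two groups on the core of compound 1. No measurement at hand speaks to what lies behind this step.

Going by these compounds alone, one pair gives only one comparison, so it remains open how the maximal response would read with a chloro group, a methoxy group, a primary amine or a carboxylic acid at this same place on the core of compound 1. Also open, as far as these compounds go, is whether the same change from cyano to fluoro would keep its size on a core whose other aryl carries a nitro group.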